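Chloro to trifluoromethyl on the benzyl ring, two cores

A few compounds are considered here, and "the series" means these few. Any claim that something is new, unique, unknown or untested is made for them only; others in the source may bear on it.

Three measured compounds share a sulfonyl amidine linked to a benzylsulfanyl arm and differ in the core and in one substituent on the benzyl ring. Compound 1 `Cc1cc(-c2ccccc2)n(/C(N)=N/S(=O)(=O)c2cc(C)c(Cl)cc2SCc2cccc(C(F)(F)F)c2)n1` and compound 2 `Cc1cc(-c2ccccc2)n(/C(N)=N/S(=O)(=O)c2cc(C)c(Cl)cc2SCc2cccc(Cl)c2)n1` carry one core; compound 3 `Cc1cc(S(=O)(=O)/N=C(\N)n2nccc2-c2ccccc2)c(SCc2ccccc2Cl)cc1Cl` and the unmeasured compound 4 `Cc1cc(S(=O)(=O)/N=C(\N)n2nccc2-c2ccccc2)c(SCc2ccccc2C(F)(F)F)cc1Cl` carry the other; the difference between the two cores is not broken down here. In a functional assay on HCT-116 cells (Homo sapiens) for cytotoxicity, read by MTT assay, with a stated time of 72 h (on this read-out higher numbers stand for weaker inhibition and lower numbers for stronger inhibition), compound 1 gives 19000 nM, compound 2 gives 18000 nM and compound 3 gives 18000 nM. Compound 2 and compound 3 agree to the digits given, and all three numbers sit within the scatter of one another.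

For the measured compounds named here, the single measured step is trifluoromethyl in place of chloro on an aromatic carbon, which gave a 1.1-fold higher number from compound 2 to compound 1 (0.02 log units; within the scatter). The same kind of change is made in trifluoromethyl in place of chloro on an aromatic carbon, the difference being that in compound 1 the entering group sits meta to a large group, while in compound 4 it sits ortho to a large group. Compound 4 is therefore expected to give 18000 nM, with a range from 9000 nM to 36000 nM. The expected step is no change at the digits printed from compound 3 to compound 4 (within the scatter), resting on the earlier step of a 1.1-fold higher number from compound 2 to compound 1 (0.02 log units; within the scatter), which stayed within the scatter.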

Compound 4, half-maximal inhibitory concentration: 16000 nM
Estimate against measurement, compound 4: 1.1-fold (0.05 log units) above; the measured number falls inside the stated range.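

In this assay, trifluoromethyl in place of chloro on the benzyl ring gives a 1.1-fold lower number from compound 3 to compound 4 (0.05 log units; within the scatter). Within these two pairs, the change carries from one core to the other with no step beyond the scatter on either core: the same change on two cores in this assay, a 1.1-fold higher number (0.02 log units; within the scatter) from compound 2 to compound 1 and a 1.1-fold lower number (0.05 log units; within the scatter) from compound 3 to compound 4, 1.2-fold (0.07 log units) apart, within the scatter of two such steps. This rests on one pair per core, the entering group sits ortho to a large group only in compound 4 among the two trifluoromethyl compounds, and the agreement is between two steps that are each within the scatter, so it does not show that the change would read the same on other cores or at other places on the ring.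

Open, on these data alone, is whether other groups on the benzyl ring, such as an amine, a carboxylic acid or a nitrile, would give a step beyond the scatter in this assay. Also open is how the two cores compare with the benzyl arm held the same, as no pair shown differs in the core alone.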